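Valine amides of benzylamines: tert-butyl to isopropyl step

The compounds below may be only part of what the source reports. "The series", "measured", "known", "first", "only" and "open" are said of these compounds alone.

Among the compounds with values here, compound 1 `Cc1ccc(CNC(=O)[C@H](N)C(C)C)cc1` is the only member with a number: in a functional assay on the whole organism (strain albino Sprague-Dawley) with Rattus norvegicus as the target, in the maximal electroshock model (on this read-out lower numbers stand for an effect already at smaller amounts and higher numbers for an effect only at larger amounts of compound), compound 1 gives 50 mg/kg. Compound 2 `CC(C)[C@@H](N)C(=O)NCc1ccc(Cl)cc1` carries the entry "not determined" (no result reported) in this assay. Compound 3 `CC(C)(C)[C@@H](N)C(=O)NCc1ccc(-c2ccccc2)cc1` likewise stands at "not determined" (no result reported) in this assay, so compound 3 offers no single number as a starting point, and one further entry in the set is also without a number. Compound 4 `CC(C)[C@@H](N)C(=O)NCc1ccc(-c2ccccc2)cc1` differs from compound 3 by hydrogen in place of methyl on a saturated chain carbon bound to three saturated chain carbons. Within the data shown here, no measured pair shows this change, so neither size nor direction of a step in this assay can be read from the data; no step beyond the scatter is assumed. The estimate rests on compound 1, which gives 50 mg/kg in this assay. Compound 4 is expected at 40 mg/kg, within 12 mg/kg to 150 mg/kg.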

Compound 4, dose for half-maximal effect: 30 mg/kg
Beside the measured number, compound 4's estimate is 1.3-fold (0.12 log units) above it; measured number inside the range.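

In this assay the isopropyl series now shows a 1.7-fold lower number from compound 1 to compound 4 (0.22 log units; within the scatter), so phenyl and methyl on this aromatic carbon cannot be told apart on this read-out. The tert-butyl to isopropyl step itself cannot be read, as compound 3 has no number. Nothing available bears on the reason for this result.

The compounds shown leave open how a methoxy group on that aromatic carbon would read. They also leave open how a longer chain in place of isopropyl would read.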